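This account rests on a few compounds, and the source may have more. Where it says the series, first, only, none or still open, it means among the compounds named here.

The shared core of these compounds carries a methyl ester and an amino group, and they differ only in the aromatic group attached to it. Compound 1 `COC(=O)c1sc2cc(-c3ccsc3)cnc2c1N` gives 12700 nM in a functional assay on MCF7 cells (Homo sapiens) for inhibition, read by sulforhodamine B assay, with a stated time of 48 h; on this read-out higher numbers stand for weaker inhibition of growth and lower numbers for stronger inhibition of growth. Compound 2 `COC(=O)c1sc2cc(-c3cccnc3)cnc2c1N` reaches only > 112000 nM in this assay, which is a limit of the measurement and not a number. Among the measured compounds shown here, the one measured step, an at least 8.8-fold higher number from compound 1 to compound 2 (0.94 log units; beyond the scatter), therefore points to a weaker result on moving from the five-membered aromatic group to the six-membered nitrogen-containing one; the limit of > 112000 nM in this assay, at which 1 of the 3 values shown sits, marks where that step ends. Compound 3 `COC(=O)c1sc2cc(-c3ccc(C#N)cc3)cnc2c1N` likewise reaches only > 75000 nM in this assay, again a limit and not a number, so its standing among the three can be told only as a limit, as the limit of > 75000 nM in this assay, at which 1 of the 3 values shown sits, shows. Compound 4 `COC(=O)c1sc2cc(-c3ccc(C(C)=O)cc3)cnc2c1N` differs from compound 3 by acetyl in place of cyano on an aromatic carbon. For the measured compounds named here, no measured step concerns this exchange: the only step that exists changes the whole aromatic group rather than a substituent on it, so it offers no direct guide in this assay. Compound 4 is therefore expected near the limit of compound 3, with a step that the limit leaves unreadable from compound 3 to compound 4 and an estimate of 80000 nM, ranging from 20000 nM to 250000 nM.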

Compound 4, concentration for 50% growth inhibition: > 150000 nM
Compound 4: only a limit was reported; the forecaster's own chance of this, stated with the estimate: 60%; middle value at least 1.8-fold (0.27 log units) from the limit.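

Compound 4 gives > 150000 nM in this assay, a limit and not a number, and compound 3 is also known only as a limit, so no step can be read between compound 3 and compound 4. The compounds shown leave open whether acetyl or cyano gives the weaker result in this assay.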